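Chloro to trifluoromethyl on a limit-bound pyrimidine amide

A few compounds are considered here, and "the series" means these few. Any claim that something is new, unique, unknown or untested is made for them only; others in the source may bear on it.

Of the compounds shown here, three built on one shared core have been tested in an assay on Jurkat cells for activation of nuclear factor NF-kappa-B complex (Homo sapiens); on this read-out lower numbers stand for stronger inhibition and higher numbers for weaker inhibition. Compound 1 `N#Cc1ncc(C(=O)Nc2cc(C(F)(F)F)cc(C(F)(F)F)c2)c(C(F)(F)F)n1` reaches only a limit of the assay, giving > 10000 nM in this assay. Compound 2 `Cc1nc(Cl)ncc1C(=O)Nc1cc(C(F)(F)F)cc(C(F)(F)F)c1` gives 50 nM in this assay. Compound 3 `O=C(Nc1cc(C(F)(F)F)cc(C(F)(F)F)c1)c1cnc(C(F)(F)F)nc1Cl` likewise reaches only a limit, giving > 10000 nM in this assay. Going by the values given here, compound 3 thus stands at the limit of > 10000 nM in this assay, at which 2 of the 3 values shown sit, with no number of its own, so its distance from compound 2 is not a measured step but shows only that compound 2 holds a value while compound 3 does not.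

The next compound, compound 4 `O=C(Nc1cc(C(F)(F)F)cc(C(F)(F)F)c1)c1cnc(C(F)(F)F)nc1C(F)(F)F`, differs from compound 3 in one place: trifluoromethyl in place of chloro on an aromatic carbon. Among the compounds with values here, no step between two measured compounds is available for this change, so the size and direction of its effect in this assay cannot be read from the measured pairs. Since compound 3 sits at a limit, a move of any size that keeps compound 4 at the same limit would appear as no change at all, and only a large gain in potency would bring compound 4 into the range where a number is reported.

Compound 4 is therefore expected to remain at the limit, and the step from compound 3 is estimated as a step that the limit leaves unreadable from compound 3 to compound 4. The estimate for compound 4 is 20000 nM, with a range from 5000 nM to 100000 nM.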

Compound 4, half-maximal inhibitory concentration: > 10000 nM
Compound 4 ended at the assay's limit; the forecaster's own chance of this, stated with the estimate: 85%; the middle value is on the limit's open side.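

In this assay compound 4 gives > 10000 nM, which is a limit of the assay and not a number. No new step can be read, as compound 4, compound 3 and compound 1 all sit at that limit: the limit of > 10000 nM in this assay, at which 3 of the 4 values shown sit.

The compounds shown leave open what trifluoromethyl in place of chloro or cyano does to inhibition when a compound gives a number.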